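Unmasking the phenol: from benzoyl ester to free hydroxy

A few compounds are considered here, and "the series" means these few. Any claim that something is new, unique, unknown or untested is made for them only; others in the source may bear on it.

Measured compounds:
- Compound 1, `COC(=O)C1=C(C)N=C(C)/C(=C(\O)OC)C1c1cc([N+](=O)[O-])ccc1O`: 100 nM
- Compound 2, `COC(=O)C1=C(C)N=C(C)/C(=C(\O)OC)C1c1cccc(OC(=O)c2ccccc2)c1`: 6310 nM
- Compound 3, `COC(=O)C1=C(C)N=C(C)/C(=C(\O)OC)C1c1cc([N+](=O)[O-])ccc1Cl`: 30.2 nM

Compound 2 gives the highest number of the three in a functional assay (muscle tissue) with Cavia porcellus as the target; a higher number here means that more compound is needed for the effect, a lower number that less compound is needed. Compound 1 comes nearest to it, and compound 3 lies furthest away; both gaps are beyond the scatter. Compound 4, `COC(=O)C1=C(C)N=C(C)/C(=C(\O)OC)C1c1cccc(O)c1`, has not yet been measured. It differs from compound 2 in one place: hydrogen in place of benzoyl on an oxygen on an aromatic ring. The cut read one bond further out is benzoyloxy to hydroxy.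

Going by the values given here, the only measured step, a 3.3-fold lower number from compound 1 to compound 3 (0.52 log units; beyond the scatter), concerns a different change, chloro in place of hydroxy on an aromatic carbon, and so offers no direct guide here. Among the compounds with values here, no measured pair shows what removing a benzoyl from an aromatic oxygen does. Given that compound 2 sits so far from compounds 1 and 3 in this assay, the free hydroxy of compound 4 might plausibly move the number down, but without a bearing step the direction and size are uncertain. Compound 4 is therefore expected to give about 2000 nM, within a range of 300 nM to 12000 nM. The estimated step amounts to a 3.2-fold lower number from compound 2 to compound 4 (0.50 log units; beyond the scatter).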

Compound 4, half-maximal effective concentration: 1000 nM
Beside the measured number, compound 4's estimate is 2.0-fold (0.30 log units) above it; low and high end bracket the measured number.
By their numbers in this assay, from the lowest: compound 3; then compound 1; then compound 4; then compound 2.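

In this assay, hydrogen in place of benzoyl on the oxygen on the aromatic ring gives a 6.3-fold lower number from compound 2 to compound 4 (0.80 log units; beyond the scatter) and so lowers the number beyond the scatter. This is the only step shown for a change on that oxygen, and it shows that the read-out responds to what the oxygen carries. Benzoyl, with its six-membered aromatic ring and its double bond outside that ring, is therefore not needed for the effect in this pair, since the number falls when benzoyloxy gives way to hydroxy, and nothing at hand bears on why it falls.

The other step shown, a 3.3-fold lower number from compound 1 to compound 3 (0.52 log units; beyond the scatter) for chloro in place of hydroxy on an aromatic carbon, belongs to a pair with a nitro group on the ring and concerns a different change, so it says nothing on whether the benzoyl step would hold in that setting. On these data alone, what a methyl ether or an acetyl ester on the same oxygen would give in this assay stays open, as does whether the number moves in step with the size of the group on that oxygen.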